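This account rests on a few compounds, and the source may have more. Where it says the series, first, only, none or still open, it means among the compounds named here.

Measured in a functional assay on HCT-116 cells (Homo sapiens) for inhibition, read by sulforhodamine B assay, with a stated time of 48 h; a higher number here means that more compound is tolerated, a lower number that less compound is tolerated:
- Compound 1 `O=C(Nc1cccc(-n2cc(-c3ccncc3)c(-c3ccc(Cl)c(O)c3)n2)c1)Nc1cccc(C(F)(F)F)c1`: > 32500 nM (a limit)
- Compound 2 `COc1cc(-c2nn(-c3cccc(NC(=O)c4cccc(C(F)(F)F)c4)c3)cc2-c2ccncc2)ccc1Cl`: > 50000 nM (a limit)

Compound 1 has no exact value in this assay, only the limit > 32500 nM. Compound 2 also has only a limit, > 50000 nM. Compound 3 `COc1cc(-c2nn(-c3cccc(NC(=O)Nc4cccc(C(F)(F)F)c4)c3)cc2-c2ccncc2)ccc1Cl` differs from compound 1 by methyl in place of hydrogen on an oxygen on an aromatic ring, hydroxy to methoxy (methyl in place of hydrogen on an oxygen on an aromatic ring). Going by the values given here, no measured step shows the effect of this change. In this assay, the expected step that the limit leaves unreadable from compound 1 to compound 3 is none beyond the usual scatter. The estimate for compound 3 is 40000 nM, with an expected range of 15000 nM to 80000 nM.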

Compound 3, concentration lethal to 50% of the cells: > 50000 nM
Compound 3: a limit, no number; the forecaster's own chance of this, stated with the estimate: 70%; at least 1.2-fold (0.09 log units) between middle value and limit.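

Going by these compounds alone, compound 3 gives only a limit, as do compound 1 and compound 2, so no step from compound 1 or compound 2 to compound 3 can be read. The compounds shown leave open whether either change shifts the lethal concentration at all.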